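A few compounds are considered here, and "the series" means these few. Any claim that something is new, unique, unknown or untested is made for them only; others in the source may bear on it.

For the measured compounds named here, compound 2, `COC(=O)c1ccc(CN2CCC(O)(Cn3cnc4c(cnn4-c4ccc(F)cc4)c3=O)CC2)cc1`, is the only member of this small set with a number to its name: in an assay on Sf21 cells for inhibition of ubiquitin carboxyl-terminal hydrolase 7 (Homo sapiens), read by spectrophotometry, with stated times of 30 min and 2 h (on this read-out lower numbers stand for stronger inhibition and higher numbers for weaker inhibition), compound 2 gives 4500 nM. Compound 1, `O=c1c2cnn(-c3ccc(F)cc3)c2ncn1CC1(O)CCN(Cc2ccccn2)CC1`, shares the same core, but in this assay compound 1 gives "not determined" (no result reported), so compound 2 stands alone and cannot be ranked against anything.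

Compound 3, `O=c1c2cnn(-c3ccc(F)cc3)c2ncn1CC1(O)CCN(Cc2ccc(F)cc2Cl)CC1`, differs from compound 2 at one site: 2-chloro-4-fluorophenyl in place of 4-(methoxycarbonyl)phenyl on a saturated chain carbon bound to an amine nitrogen in a ring. Going by the values given here, no pair of measured compounds shows what such a swap does on this assay, so the direction of the step rests on nothing beyond the one value of compound 2. The expected step from compound 2 to compound 3 in this assay is a 1.5-fold lower number from compound 2 to compound 3 (0.18 log units; within the scatter), small and uncertain, and could lie within the scatter.

For compound 3 the expected half-maximal inhibitory concentration is 3000 nM, with a range from 800 nM to 12000 nM.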

Compound 3, half-maximal inhibitory concentration: 1600 nM
Estimate against measurement, compound 3: 1.9-fold (0.27 log units) above; low and high end bracket the measured number.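

Compound 3 gives this small set its first comparison: this assay shows a 2.8-fold lower number from compound 2 to compound 3 (0.45 log units; beyond the scatter) and so establishes that the group on a saturated chain carbon bound to an amine nitrogen in a ring can change the read-out by more than the usual scatter. It also shows that the methoxycarbonyl group of compound 2 is not required for a measurable number, as compound 3 lacks it and still gives a lower one. Nothing in the material shown explains this step.

On these data alone, the swap changes several features at once, so it remains open whether the chlorine, the fluorine or the loss of the methoxycarbonyl group carries the step. As far as these compounds go, it also remains open how an unsubstituted phenyl, or a carboxylic acid in place of the methoxycarbonyl group, would read at this position, and compound 1 offers no number to help settle either question.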